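Vinylphenyl for methylindazolyl on the shared core

A few compounds are considered here, and "the series" means these few. Any claim that something is new, unique, unknown or untested is made for them only; others in the source may bear on it.

Compound 3 `COc1cc(-c2ccnc3cc(-c4ccc5cnn(C)c5c4)nn23)cc(OC)c1OC` gives 2440 nM in a functional assay on HCT-116 cells (Homo sapiens) for inhibition, read by CCK-8 assay, with a stated time of 48 h; a lower number here means a stronger inhibitor, a higher number a weaker inhibitor. Among the two numbers in this assay it is the highest, with compound 2 `COc1cc(-c2ccnc3cc(-c4ccc(N(C)C)cc4)nn23)cc(OC)c1OC` nearest at 2050 nM; the gap is a 1.2-fold higher number from compound 2 to compound 3 (0.08 log units; within the scatter). Compound 1 `COc1cc(-c2ccnc3cc(-c4ccc(C(C)(C)C)cc4)nn23)cc(OC)c1OC` is recorded in this assay only as a limit, > 10000 nM, namely (the limit of > 10000 nM in this assay, at which 1 of the 3 values shown sits).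

Compound 4 `C=Cc1ccc(-c2cc3nccc(-c4cc(OC)c(OC)c(OC)c4)n3n2)cc1` differs from compound 3 in one place: 4-vinylphenyl in place of 1-methyl-1H-indazol-6-yl on an aromatic carbon. Among the compounds with values here, two measured steps bear on this change. The step of an at least 4.0-fold lower number from compound 1 to compound 3 (0.61 log units; beyond the scatter) shows that moving from 4-(tert-butyl)phenyl to 1-methyl-1H-indazol-6-yl brought a clearly lower number, while the step of a 1.2-fold higher number from compound 2 to compound 3 (0.08 log units; within the scatter) shows that the exchange of 4-(dimethylamino)phenyl for the same group changed nothing beyond the scatter. The entering 4-vinylphenyl is a six-membered aromatic ring of carbon only with no hydrogen-bond acceptors, which places compound 4 closer to compound 1 than to compound 3 or compound 2.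

A higher number is therefore expected for compound 4, a step of about a 2.5-fold higher number from compound 3 to compound 4 (0.39 log units; beyond the scatter). Compound 4 is estimated at 6000 nM, within 2000 nM to 20000 nM, and a limit like that of compound 1 is a real possibility.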

Compound 4, half-maximal inhibitory concentration: 1060 nM
For compound 4 the middle estimate is 5.7-fold (0.75 log units) above the measured one; measured number outside the range, below it.
By their numbers in this assay, from the lowest: compounds 4, 2 and 3 (each within the scatter of the next, the first and the last beyond it). At a limit, above all of these: compound 1.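

In this assay, 4-vinylphenyl on this aromatic carbon gives a 2.3-fold lower number from compound 3 to compound 4 (0.36 log units; beyond the scatter) and thus shows that an entering group with a single carbon-only aromatic ring and no hydrogen-bond acceptors is tolerated here, and that the hydrogen-bond acceptors of 1-methyl-1H-indazol-6-yl are not required for a number of this size. Against the dimethylamino group, vinyl gives a 1.9-fold lower number from compound 2 to compound 4 (0.29 log units; within the scatter) and does not separate the two compounds, so the 4-substituted phenyl series now holds two members that read alike and one that stands apart. That third member is compound 1, and vinyl in place of tert-butyl gives an at least 9.4-fold lower number from compound 1 to compound 4 (0.97 log units; beyond the scatter) as a step with only a lower bound on its size, since the value of compound 1 is a limit: the limit of > 10000 nM in this assay, at which 1 of the 4 values shown sits.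

On these data alone, whether the double bond outside the aromatic ring matters stays open, and an ethyl group or an unsubstituted phenyl ring at this place would address that. Also open, as far as these compounds go, is how this position responds to a primary amine or a carboxylic acid on the phenyl ring, and whether any of these numbers would hold in a second cell line.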